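Moving the nitrile on the aryl group of the ring

The source may hold more compounds than are shown below. What is called first, only, known or untested is meant among the compounds shown, and "the series" means these compounds.

Compound 1 `COc1ccc(-n2cc(COc3c(/C=C\C(=O)O)ccc(OC)c3CC=C(C)C)nn2)cc1` has no reported result in a functional assay on A-431 cells (Homo sapiens) for cytotoxicity, read by MTT assay, with a stated time of 24 h; a higher number here means a weaker inhibitor, a lower number a stronger inhibitor; its entry there reads "not determined" (no result reported). Going by the values given here, two related compounds supply the only numbers. Compound 2 `COc1ccc(/C=C\C(=O)O)c(OCc2cn(-c3ccc(C#N)cc3)nn2)c1CC=C(C)C` gives 23000 nM in this assay, and compound 3 `COc1ccc(/C=C\C(=O)O)c(OCc2cn(-c3cccnc3Cl)nn2)c1CC=C(C)C` gives 32600 nM. Exchanging the aryl group on the aromatic nitrogen produces a 1.4-fold higher number from compound 2 to compound 3 (0.15 log units; within the scatter), a shift that stays within the scatter. Compound 4 `COc1ccc(/C=C\C(=O)O)c(OCc2cn(-c3ccccc3C#N)nn2)c1CC=C(C)C` differs from compound 1 by 2-cyanophenyl in place of 4-methoxyphenyl on an aromatic nitrogen. Among the compounds with values here, compound 1 lacks a number; no measured step starts from it. Within the data shown here, the step from compound 2 to compound 3 is the only one that touches a change at this position, and it was small; compound 2, which carries a nitrile on the aryl group as compound 4 does, and compound 3 lie in the same region of this assay. Compound 4 is therefore expected to land near those two, with no step beyond the scatter predicted in either direction. The estimate for compound 4 in this assay is 26000 nM, with a range from 10000 nM to 65000 nM.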

Compound 4, half-maximal inhibitory concentration: 10300 nM
Beside the measured number, compound 4's estimate is 2.5-fold (0.40 log units) above it, and the stated range covers the measured number.
By their numbers in this assay, from the lowest: compound 4; then compounds 2 and 3 (each within the scatter of the next).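

In this assay, moving the nitrile from 4-cyanophenyl to 2-cyanophenyl on the aromatic nitrogen gives a 2.2-fold lower number from compound 2 to compound 4 (0.35 log units; beyond the scatter), and putting 2-cyanophenyl in place of 2-chloropyridin-3-yl gives a 3.2-fold lower number from compound 3 to compound 4 (0.50 log units; beyond the scatter). Going by these compounds alone, the one earlier step at this position stayed within the scatter, so these two are the first to show that the group on this nitrogen can move the number beyond it, and the pair of compound 2 and compound 4 shows that the place of the nitrile on the phenyl ring matters, since both carry that same group. No data shown here bear on why the number falls with this change.

As far as these compounds go, compound 1 has no number, so the steps from it to the other compounds cannot be read, and the effect of replacing 4-methoxyphenyl stays unknown. From the compounds shown here alone, it also remains open whether the lower number belongs to the nitrile itself, or whether a 2-aminophenyl or 2-methoxyphenyl group on the same nitrogen would give a similar value.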